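The source may hold more compounds than are shown below. What is called first, only, known or untested is meant among the compounds shown, and "the series" means these compounds.

Compound 3 `Nc1ccccc1NC(=O)c1ccc(Cn2cnc3c(NCc4ccccc4)nc(Cl)nc32)cc1` gives 62.8% in a functional assay on HepG2 cells (Homo sapiens) for antiproliferative activity, read by CCK-8 assay, with a stated time of 72 h, tested at 8 uM; a higher number here means a stronger effect of the compound at the concentration tested, a lower number a weaker effect. Among the three measured compounds it stands second: compound 2 `Nc1ccccc1NC(=O)c1ccc(Cn2cnc3c(Nc4ccccc4)nc(Cl)nc32)cc1` gives 74.8%, and compound 1 `CC(C)n1cnc2c(Nc3ccccc3)nc(NCOCc3ccc(/C=C/C(=O)Nc4ccccc4N)cc3)nc21` gives 40.8%. Compound 4 `Nc1ccccc1NC(=O)c1ccc(Cn2cnc3c(Nc4cccc(OC(F)(F)F)c4)nc(Cl)nc32)cc1` differs from compound 3 by 3-(trifluoromethoxy)phenyl in place of benzyl on a nitrogen on an aromatic ring. Among the measured compounds shown here, the one measured step that bears on this change is a number 12 percentage points lower from compound 2 to compound 3 (beyond the scatter), which is the opposite swap, an aryl for a benzyl, on a nitrogen on an aromatic ring. Compound 4 is expected to recover roughly that amount, an estimated step of a number 9.2 percentage points higher from compound 3 to compound 4 (within the scatter) in this assay, even though the group entering is not the phenyl that left. The estimate for compound 4 is 72%, within 55% to 86%.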

Compound 4, a percentage reported as inhibition, at one concentration (the size of the read-out at that concentration, not a potency): 31.2%
The estimate for compound 4 lay 40.8 percentage points above the measured number, and the stated range ends above it.
By their numbers in this assay, from the lowest: compounds 4 and 1 (each within the scatter of the next); then compound 3; then compound 2.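

An aryl group on this nitrogen does not by itself give the higher number: the step of a number 31.6 percentage points lower from compound 3 to compound 4 (beyond the scatter) shows that the advantage of plain phenyl does not extend to this substituted ring. The trifluoromethoxy group in place of hydrogen on an aromatic carbon marks the change, with a number 43.6 percentage points lower from compound 2 to compound 4 (beyond the scatter) on that single swap. No evidence here explains this loss. The compounds shown leave open whether methoxy, fluorine or an amine on that phenyl ring would keep the number of compound 2 or lose it as trifluoromethoxy does.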